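Removing a ring cyano group on two urea cores

This account rests on a few compounds, and the source may have more. Where it says the series, first, only, none or still open, it means among the compounds named here.

Measured compounds:
- Compound 1, `Cc1ccc(CN2CCC(NC(=O)NCc3ccc(-c4cccc(C#N)c4)cc3)CC2)cc1`, gives 411 nM in an in vitro functional assay on HEK293 cells for antagonist activity at melanin-concentrating hormone receptor 1 (Homo sapiens), read by GTPgammaS binding, with a stated time of 45 min; on this read-out higher numbers stand for weaker inhibition and lower numbers for stronger inhibition.
- Compound 2, `Cc1ccc(CN2CCC(NC(=O)NCc3ccc(-c4ccccc4)cc3)CC2)cc1`, gives 1060 nM in this assay.
- Compound 3, `Cc1ccc(CN2CCC(CCN(Cc3ccc(-c4cccc(C#N)c4)cc3)C(=O)NC(C)C)CC2)cc1`, gives 1010 nM in this assay.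

Compounds 1 and 2 share one core and differ in a single place: hydrogen in place of cyano on an aromatic carbon. That change produced a 2.6-fold higher number from compound 1 to compound 2 (0.41 log units; beyond the scatter), so taking the cyano group away made the inhibition weaker on this pair. Compound 3 carries a different core; how its core differs from that of compound 1 is not broken down here. Its value lies within the usual scatter of the value of compound 2, so no order between those two can be claimed, while it sits clearly apart from compound 1.

Compound 4, `Cc1ccc(CN2CCC(CCN(Cc3ccc(-c4ccccc4)cc3)C(=O)NC(C)C)CC2)cc1`, has not yet been measured. It is made from compound 3 by the same change, (hydrogen in place of cyano on an aromatic carbon), at a place described in the same words as before. Because the same change on the first core gave a 2.6-fold higher number from compound 1 to compound 2 (0.41 log units; beyond the scatter), a step of similar size and direction is expected on the second core. Compound 4 is therefore expected to show a 2.6-fold higher number from compound 3 to compound 4 (0.41 log units; beyond the scatter). This expectation rests on one measured pair only, so it carries real uncertainty. In this assay compound 4 is estimated at 2600 nM, with a likely range from 1200 nM to 5600 nM.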

Compound 4, antagonist equilibrium constant: 220 nM
Beside the measured number, compound 4's estimate is 12-fold (1.07 log units) above it; the measured number lies below the stated range.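

On the second core, putting hydrogen in place of cyano gave a 4.6-fold lower number from compound 3 to compound 4 (0.66 log units; beyond the scatter) in this assay, so here the inhibition became stronger, whereas on the first core it became weaker. This shows that the change does not carry over reliably between these two cores: a step measured on one core, even one clearly beyond the scatter, did not predict the direction of the step on the other. It does not show why the direction reverses, and two pairs cannot reveal how the change would behave on any further core, but the two steps clearly disagree: the same change on two cores in this assay, a 2.6-fold higher number (0.41 log units; beyond the scatter) from compound 1 to compound 2 and a 4.6-fold lower number (0.66 log units; beyond the scatter) from compound 3 to compound 4, 12-fold (1.07 log units) apart, beyond the scatter of two such steps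

The compounds shown have only cyano or hydrogen at this place, so it remains open whether a fluorine atom or a methoxy group there would behave like cyano or like hydrogen on each core. Only two cores are shown, and it also remains open which part of the difference between them goes with the reversal.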